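A Non-Aromatic Ring Replaces the Chloropyridinyl Group

A few compounds are considered here, and "the series" means these few. Any claim that something is new, unique, unknown or untested is made for them only; others in the source may bear on it.

Three compounds share a core and differ only in the group on the amide-type nitrogen. Compound 1 `COc1ccc(C(=O)Nc2ccccc2Br)cc1OC1CCCC1` gives 130 nM in an assay on isolated protein for inhibition of phosphodiesterase 4A (Sus scrofa); on this read-out higher numbers stand for weaker inhibition and lower numbers for stronger inhibition. Compound 2 `COc1ccc(C(=O)Nc2ccccc2O)cc1OC1CCCC1` gives 1300 nM in this assay, and compound 3 `COc1ccc(C(=O)Nc2ccncc2Cl)cc1OC1CCCC1` gives 16 nM. Compound 3 thus has the lowest number of the three: the step of an 8.1-fold lower number from compound 1 to compound 3 (0.91 log units; beyond the scatter) and the step of an 81-fold lower number from compound 2 to compound 3 (1.91 log units; beyond the scatter) both lie beyond the scatter, and the step of a 10-fold higher number from compound 1 to compound 2 (1.00 log units; beyond the scatter) shows how much the group on this nitrogen can matter.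

Compound 4 `COc1ccc(C(=O)NN2C(Cl)=NC=CC2Cl)cc1OC1CCCC1` has not been measured. Relative to compound 3, the change is a group of 8 heavy atoms (4 carbon, 2 nitrogen, 2 chlorine; one six-membered non-aromatic ring with 2 hetero atoms) in place of a group of 7 heavy atoms (5 carbon, 1 nitrogen, 1 chlorine; one six-membered aromatic ring with 1 hetero atom), on an amide-type nitrogen. The steps from compound 1 and compound 2 to compound 3 bear on it in that they also change the group on the amide-type nitrogen, but each of them exchanges one aromatic ring for another, whereas here the aromatic ring leaves and a non-aromatic ring with two double bonds outside aromatic rings enters. Among the measured compounds shown here, no measured step covers such a change, so the expectation is uncertain. Compound 4 is expected to show a step of a 16-fold higher number from compound 3 to compound 4 (1.19 log units; beyond the scatter) in this assay, toward weaker inhibition. Compound 4 is therefore estimated at 250 nM, with a range from 40 nM to 1600 nM.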

Compound 4, half-maximal inhibitory concentration: 400 nM
Estimate against measurement, compound 4: 1.6-fold (0.20 log units) below, and the stated range covers the measured number.
By their numbers in this assay, from the lowest: compound 3; then compound 1; then compound 4; then compound 2.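

In this assay, the step (a 25-fold higher number from compound 3 to compound 4 (1.40 log units; beyond the scatter)) shows that compound 3's inhibition does not survive when its aromatic ring on the amide-type nitrogen gives way to this non-aromatic ring with 2 double bonds outside aromatic rings, the first such exchange seen at this position. Yet an aromatic ring here is not needed for measurable inhibition, since the new group falls between the two phenyl-bearing compounds, with steps beyond the scatter on both sides (a 3.3-fold lower number from compound 2 to compound 4 (0.51 log units; beyond the scatter); a 3.1-fold higher number from compound 1 to compound 4 (0.49 log units; beyond the scatter)), so the 2-bromophenyl group outperforms it and the 2-hydroxyphenyl group does not. No measured information on these compounds accounts for any of these differences.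

What the compounds leave open is which part of the exchange matters, as compound 4 alters the ring type, the number of ring hetero atoms and the number of chlorine atoms all at once, and no compound shown varies one of these alone. On these data alone, how a fully saturated cyclohexyl group, or a non-aromatic ring carrying no chlorine, would behave on this nitrogen also remains unknown.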